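The source may report more compounds than this note shows. Statements on the series, on what has been measured and on what is new or still open speak of the compounds shown alone.

Compound 1 `O=C(/C(=C\c1ccc(Cl)cc1)S(=O)(=O)c1ccc(Br)cc1)c1ccc(Br)cc1` gives 50000 nM in a functional assay on DU-145 cells (Homo sapiens) for inhibition, read by trypan blue exclusion, with a stated time of 96 h; on this read-out higher numbers stand for weaker inhibition of growth and lower numbers for stronger inhibition of growth. Compound 2 `O=C(/C(=C\c1ccc(Cl)cc1Cl)S(=O)(=O)c1ccc(Br)cc1)c1ccc(Br)cc1` differs from it by chloro in place of hydrogen on an aromatic carbon and gives 10000 nM, so that the change brought a 5.0-fold lower number from compound 1 to compound 2 (0.70 log units; beyond the scatter). Compound 3 `O=C(/C(=C\c1ccc(Cl)cc1)Sc1ccc(Br)cc1)c1ccc(Br)cc1` gives 1000 nM in this assay, the lowest of the three numbers; how its core differs from that of compound 1 is not broken down here. Compound 4 `O=C(/C(=C\c1ccc(Cl)cc1Cl)Sc1ccc(Br)cc1)c1ccc(Br)cc1` stands to compound 3 as compound 2 stands to compound 1, the change being (chloro in place of hydrogen on an aromatic carbon), the same change made on the core of compound 3. Because a 5.0-fold lower number from compound 1 to compound 2 (0.70 log units; beyond the scatter) was seen for this change once, a similar step, a 5.0-fold lower number from compound 3 to compound 4 (0.70 log units; beyond the scatter), is expected here. Compound 4 is therefore estimated to give 200 nM in this assay, with a likely range from 70 nM to 700 nM.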

Compound 4, concentration for 50% growth inhibition: 1000 nM
For compound 4 the middle estimate is 5.0-fold (0.70 log units) below the measured one; the measured number lies above the stated range.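

In this assay, the change from 4-chlorophenyl to 2,4-dichlorophenyl brought no change at the digits printed from compound 3 to compound 4 (within the scatter). The step seen on the core of compound 1 therefore did not carry over to the core of compound 3, and the two cores responded differently: the same change on two cores in this assay, a 5.0-fold lower number (0.70 log units; beyond the scatter) from compound 1 to compound 2 and no change at the digits printed (within the scatter) from compound 3 to compound 4, 5.0-fold (0.70 log units) apart, beyond the scatter of two such steps. This shows that a lower number on one core cannot be assumed on the other in this series, but with a single pair on each core it does not show which difference between the cores is responsible, or how the change would behave on any further core.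

The compounds shown leave open whether a fluoro group, a methoxy group or an amine in place of the added chloro would also respond differently on the two cores.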